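A few compounds are considered here, and "the series" means these few. Any claim that something is new, unique, unknown or untested is made for them only; others in the source may bear on it.

In a functional assay on M21 cells (Homo sapiens) for antiproliferative activity, read by sulforhodamine B assay, with a stated time of 48 h (a lower number here means a stronger inhibitor, a higher number a weaker inhibitor), two compounds with a shared core have been measured so far. Compound 1 `CN1CCN(c2ccc(S(=O)(=O)Oc3c(Cl)cc(Cl)cc3Cl)cc2)C1=O` gives 1700 nM, and compound 2 `Cc1cccc(OS(=O)(=O)c2ccc(N3CCN(C)C3=O)cc2)c1` gives 2300 nM. These two values lie within the usual scatter of each other, so compound 2 stands alongside compound 1 and the pair sets no order.

Compound 3 `CN1CCN(c2ccc(S(=O)(=O)Oc3cccc(I)c3)cc2)C1=O` is still to be measured in this assay. It departs from compound 2 at a single place: iodo in place of methyl on an aromatic carbon. This exchange turns 3-methylphenyl into 3-iodophenyl.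

For the measured compounds named here, no measured pair differs in only one place, so the data offer no direct guide to this exchange. Going by the values given here, the only evidence is the narrow spread between compound 1 at 1700 nM and compound 2 at 2300 nM. On that basis, no step beyond the scatter is expected in this assay, in either direction. The estimated change is small, a 1.2-fold lower number from compound 2 to compound 3 (0.08 log units; within the scatter), and stays within the scatter. For compound 3 the expected value is 1900 nM, with an estimated range from 800 nM to 4500 nM.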

Compound 3, half-maximal inhibitory concentration: 400 nM
The estimate for compound 3 lay 4.8-fold (0.68 log units) above the measured number; measured number outside the range, below it.
By their numbers in this assay, from the lowest: compound 3; then compounds 1 and 2 (each within the scatter of the next).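

In this assay, for the compounds shown here, iodo in place of methyl on an aromatic carbon, meta to a large group, brings a 5.8-fold lower number from compound 2 to compound 3 (0.76 log units; beyond the scatter) and is the only step in this set that can be read for a change in one place. It shows that this position is not indifferent: an exchange of one heavy atom for one heavy atom, with no ring, hydrogen-bond donor, hydrogen-bond acceptor or net charge on either side, is enough to move the number beyond the scatter, something the narrow spread of the earlier pair could not show. Nothing at hand gives a measured account of what lies behind this step.

The compounds shown leave open whether the gain belongs to iodo itself or would also come with another group at this place, such as bromo, chloro, methoxy or nitrile, and how 3-iodophenyl compares with plain phenyl carrying no group there. They also leave open whether iodo would act in the same way at another carbon of this ring, or alongside a different group on the other side of the shared core.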